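Bromo for chloro on the aryl ketone of a guanylhydrazone chalcone

The source may hold more compounds than are shown below. What is called first, only, known or untested is meant among the compounds shown, and "the series" means these compounds.

Measured compounds:
compound 1 `N=C(N)N/N=C/c1ccc(/C=C/C(=O)c2cccc(Br)c2)cc1` gives 49.7%
compound 2 `N=C(N)N/N=C/c1ccc(/C=C/C(=O)c2cccc(Cl)c2)cc1` gives 80.7%
compound 3 `N=C(N)N/N=C/c1ccc(/C=C/C(=O)c2ccccc2Cl)cc1` gives 84.1%

All three were tested in a functional assay on the whole organism (Ear) for inhibition, with Mus musculus as the target, with a stated time of 30 min, at a dose of 100 mg/kg by the intraperitoneal route; a lower number here means less inhibition, a higher number more inhibition at the dose given (going by the name of the read-out). Compounds 2 and 3 share the same atoms, joined differently: 2-chlorophenyl in place of 3-chlorophenyl on a carbonyl carbon. The step is a number 3.4 percentage points higher from compound 2 to compound 3 (within the scatter). Compounds 2 and 1 differ by bromo in place of chloro on an aromatic carbon, and the step is a number 31 percentage points lower from compound 2 to compound 1 (beyond the scatter). Compound 4 `N=C(N)N/N=C/c1ccc(/C=C/C(=O)c2ccccc2Br)cc1` is not yet measured. It differs from compound 3 by bromo in place of chloro on an aromatic carbon; this is the same kind of change as from compound 2 to compound 1, but there the place was meta to a large group and here it is ortho to a large group. Because a number 31 percentage points lower from compound 2 to compound 1 (beyond the scatter) was large, compound 4 is expected to lose ground too, but the place differs, so a smaller step is estimated: a number 19.1 percentage points lower from compound 3 to compound 4 (beyond the scatter). Compound 4 is therefore expected to give about 65%, between 42% and 86%.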

Compound 4, a percentage reported as inhibition, in the whole organism at one dose (the size of the read-out at that dose, not a potency): 78.3%
Estimate against measurement, compound 4: 13.3 percentage points below; low and high end bracket the measured number.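

In this assay, bromo in place of chloro does not give a step of the same size in the two settings: the same change on two cores in this assay, a number 31 percentage points lower (beyond the scatter) from compound 2 to compound 1 and a number 5.8 percentage points lower (within the scatter) from compound 3 to compound 4, 25.2 percentage points apart, beyond the scatter of two such steps Measured against the other compounds, the new result reads as a number 5.8 percentage points lower from compound 3 to compound 4 (within the scatter), a number 2.4 percentage points lower from compound 2 to compound 4 (within the scatter) and a number 28.6 percentage points higher from compound 1 to compound 4 (beyond the scatter), which leaves compound 1 alone apart from the other three. Among the compounds shown here, the large loss seen with the 3-bromophenyl group therefore did not carry over to the 2-bromophenyl group, but this rests on only one pair of each kind at a single dose and does not show why the steps differ.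

The compounds shown leave open whether the same gap would appear with fluoro, methoxy or an amine on that ring. They also leave open how the change would behave with the guanylhydrazone replaced.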